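Aryl variation on the shared core of compound 1

This account rests on a few compounds, and the source may have more. Where it says the series, first, only, none or still open, it means among the compounds named here.

Measured so far in a functional assay on NCI-H460 cells (Homo sapiens) for inhibition, read by sulforhodamine B assay, with a stated time of 48 h; on this read-out higher numbers stand for weaker inhibition of growth and lower numbers for stronger inhibition of growth:
compound 1 `COc1ccc(/C=N/NC(=S)NC(C)(C)[C@H]2CC=C(C)CC2)cc1` gives 22500 nM
compound 2 `CC1=CC[C@H](C(C)(C)NC(=S)N/N=C/c2ccc(N(C)C)cc2)CC1` gives 53400 nM

Compound 1 has the lowest number of the two; the nearest is compound 2, reached by a 2.4-fold higher number from compound 1 to compound 2 (0.38 log units; beyond the scatter), a dimethylamino in place of methoxy on an aromatic carbon. Compound 3 `CC1=CC[C@H](C(C)(C)NC(=S)N/N=C/c2ccccc2Cl)CC1` is not yet measured in this assay. It differs from compound 1 by 2-chlorophenyl in place of 4-methoxyphenyl on a carbon with a double bond to nitrogen. For the measured compounds named here, the one measured step, from compound 1 to compound 2, is a swap on the same aryl group and was modest in size; it offers no direct guide to a 2-chlorophenyl, and no other aryl variant has been measured. With no basis for a shift in either direction, compound 3 is expected to stay close to compound 1, with a step of a 1.1-fold higher number from compound 1 to compound 3 (0.05 log units; within the scatter) not beyond the scatter. The estimate for compound 3 in this assay is 25000 nM, between 10000 nM and 62000 nM.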

Compound 3, concentration for 50% growth inhibition: 64500 nM
The estimate for compound 3 lay 2.6-fold (0.41 log units) below the measured number; measured number above the stated range.
By their numbers in this assay, from the lowest: compound 1; then compounds 2 and 3 (each within the scatter of the next).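

In this assay, 2-chlorophenyl in place of 4-methoxyphenyl on the carbon with a double bond to nitrogen gives a 2.9-fold higher number from compound 1 to compound 3 (0.46 log units; beyond the scatter), so this position responds to exchange of the whole aryl substituent and not only to the swap behind a 2.4-fold higher number from compound 1 to compound 2 (0.38 log units; beyond the scatter). Both aryl changes are modest and both raise the number, leaving compound 1 the lowest of the three, while compound 2 and compound 3 lie within the scatter of each other. No measurement at hand explains the shift.

Going by these compounds, whether an unsubstituted phenyl, or an aryl group carrying a hydroxyl or a carboxylic acid, would fall below compound 1 stays open. The compounds shown also leave the rest of the shared core unvaried, so its part in the read-out of this assay is unknown.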